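Two chlorines in place of a nitrile

A few compounds are considered here, and "the series" means these few. Any claim that something is new, unique, unknown or untested is made for them only; others in the source may bear on it.

Compound 2 `CC/C(=C(/c1ccc(/C=C/C(=O)O)cc1)c1cc2ccccc2[nH]1)c1ccc(C#N)cc1` and compound 1 `CC/C(=C(/c1ccc(/C=C/C(=O)O)cc1)c1cc2ccccc2[nH]1)c1ccc(Cl)cc1` share one core and differ only in the group on one aromatic carbon. In a functional assay on MCF7 cells (Homo sapiens) for inhibition (a lower number here means a stronger inhibitor, a higher number a weaker inhibitor), compound 1 gives 343 nM and compound 2 gives 278 nM in the same test. The step of a 1.2-fold lower number from compound 1 to compound 2 (0.09 log units; within the scatter) is small, so neither can be called the stronger inhibitor, and compound 2 simply holds the lower of the two numbers seen so far. Compound 3 `CC/C(=C(/c1ccc(/C=C/C(=O)O)cc1)c1cc2ccccc2[nH]1)c1ccc(Cl)cc1Cl` is the next compound to be measured, and its change is 2,4-dichlorophenyl in place of 4-cyanophenyl on a double-bonded chain carbon bound to a double-bonded chain carbon and a saturated chain carbon as counted from the two structures. Going by the values given here, only one measured step bears on this change, namely a 1.2-fold lower number from compound 1 to compound 2 (0.09 log units; within the scatter) which swapped a single chloro for a cyano on an aromatic carbon and did not move the number beyond the scatter. Compound 3 carries the chloro of compound 1 together with a second chlorine, and nothing measured here speaks to that second chlorine. The expectation in this assay is therefore a step of a 1.3-fold higher number from compound 2 to compound 3 (0.10 log units; within the scatter) from compound 2, meaning no clear change beyond the scatter. Compound 3 is estimated at 350 nM with a range from 140 nM to 900 nM in that assay.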

Compound 3, half-maximal inhibitory concentration: 11 nM
Compound 3: the middle estimate sits 32-fold (1.50 log units) above what was measured; measured number below the stated range.
By their numbers in this assay, from the lowest: compound 3; then compounds 2 and 1 (each within the scatter of the next).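

Going by these compounds alone, the added chloro in place of hydrogen on an aromatic carbon gives a 31-fold lower number from compound 1 to compound 3 (1.49 log units; beyond the scatter) in this assay and is the one change here that separates compound 1 from compound 3. Replacing 4-cyanophenyl with 2,4-dichlorophenyl on the double-bonded chain carbon gives a 25-fold lower number from compound 2 to compound 3 (1.40 log units; beyond the scatter) in the same test, whereas the earlier swap of cyano for chloro gave only a 1.2-fold lower number from compound 1 to compound 2 (0.09 log units; within the scatter) and could not show that this part of the molecule responds so strongly to change. The result therefore places the large difference on the second chlorine rather than on the choice between the first chlorine and the nitrile, but no supporting measurement is available to explain why the number falls so far.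

From the compounds shown here alone, only hydrogen and chloro are compared at that aromatic carbon, so it remains open whether the gain is particular to chlorine or would also appear with a fluoro, a methyl or a methoxy group there. Going by these compounds, it is also open whether the added chlorine would have a similar effect on a ring that carries a nitrile in place of the first chlorine.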